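A few compounds are considered here, and "the series" means these few. Any claim that something is new, unique, unknown or untested is made for them only; others in the source may bear on it.

Measured so far:
- compound 1 `COc1ccc(-c2cn3cc(C4=CCN(C(=O)c5ccccc5)CC4)ccc3n2)cc1OC`: 10200 nM in a functional assay on HeLa cells (Homo sapiens) for antiproliferative activity, read by MTT assay, with a stated time of 48 h; on this read-out lower numbers stand for stronger inhibition and higher numbers for weaker inhibition
- compound 2 `COc1ccc(-c2cn3cc(C4=CCN(C(=O)C5CC5)CC4)ccc3n2)cc1OC`: 15800 nM in this assay

Compound 2 gives the highest of the two numbers, with compound 1 nearest; the step of a 1.5-fold higher number from compound 1 to compound 2 (0.19 log units; within the scatter) is within the scatter, so the two are not separated.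

Compound 3 `COc1ccc(-c2cn3cc(C4=CCN(C(=O)c5cccc(C(F)(F)F)c5)CC4)ccc3n2)cc1OC` is unmeasured. Relative to compound 2 the change is 3-(trifluoromethyl)phenyl in place of cyclopropyl on a carbonyl carbon. Among the measured compounds shown here, the only measured step that bears on this place is a 1.5-fold higher number from compound 1 to compound 2 (0.19 log units; within the scatter), which swaps phenyl against cyclopropyl on the same carbonyl carbon and stays within the scatter. For the measured compounds named here, compound 3 returns to an aromatic ring at that position, now carrying a trifluoromethyl group, for which there is no precedent. The expectation is therefore a number close to those of compound 1 and compound 2, with at most a modest move toward stronger inhibition; the estimated step is a 2.0-fold lower number from compound 2 to compound 3 (0.30 log units; within the scatter). Compound 3 is estimated at 8000 nM in this assay, expected between 3000 nM and 25000 nM.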

Compound 3, half-maximal inhibitory concentration: 4860 nM
Beside the measured number, compound 3's estimate is 1.6-fold (0.22 log units) above it; the range from low to high includes it.
By their numbers in this assay, from the lowest: compound 3; then compounds 1 and 2 (each within the scatter of the next).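

In this assay the group on the carbonyl carbon can move the number beyond the scatter, which the swap between phenyl and cyclopropyl did not show: 3-(trifluoromethyl)phenyl in place of cyclopropyl gives a 3.3-fold lower number from compound 2 to compound 3 (0.51 log units; beyond the scatter) as a modest step. Trifluoromethyl in place of hydrogen on an aromatic carbon also separates the compounds, with a 2.1-fold lower number from compound 1 to compound 3 (0.32 log units; beyond the scatter), so an aromatic ring alone does not account for the difference, as compound 1 and compound 2 remain unseparated. No supporting data bear on why these steps occur.

A single substituted ring cannot show whether the step is specific to trifluoromethyl or would also appear with chlorine, methoxy or a nitrile. Also open, from the compounds shown here alone, are the outcome with trifluoromethyl elsewhere on the phenyl ring and with an amine or a carboxylic acid on that ring.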